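A few compounds are considered here, and "the series" means these few. Any claim that something is new, unique, unknown or untested is made for them only; others in the source may bear on it.

Working notes on the series.

Compound 3, `COc1cc(/C=C/C(=O)c2cccc(NC(=O)c3ccccc3)c2)ccc1O`, gives 48% in a functional assay on HUVEC cells (Homo sapiens) for inhibition, tested at 5 ug/mL; on this read-out lower numbers stand for a weaker effect and higher numbers for a stronger effect at the one concentration tested. It stands second highest of the three measured numbers. Its nearest neighbour is compound 2, `COc1cc(/C=C/C(=O)c2cccc(N)c2)ccc1O`, which gives 50% in this assay; the step of a number 2 percentage points lower from compound 2 to compound 3 (within the scatter) lies within the scatter, so the two cannot be ordered. The furthest is compound 1, `COc1cc(/C=C/C(=O)c2cccc(NC(=O)c3ccc(Cl)c(Cl)c3)c2)ccc1O`, which gives 5% in this assay; the step of a number 43 percentage points higher from compound 1 to compound 3 (beyond the scatter) is large.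

Compound 4, `CCOC(=O)C(=O)Nc1cccc(C(=O)/C=C/c2ccc(O)c(OC)c2)c1`, is not yet measured. It differs from compound 3 as follows: ethoxycarbonyl in place of phenyl on a carbonyl carbon. For the measured compounds named here, two measured steps bear on this. The step of a number 43 percentage points higher from compound 1 to compound 3 (beyond the scatter) shows that exchanging the group on the carbonyl carbon moved the read-out strongly, while the step of a number 2 percentage points lower from compound 2 to compound 3 (within the scatter) shows that the benzoyl group itself on the nitrogen gave no change beyond the scatter against hydrogen. Going by the values given here, no measured step exchanges phenyl on this carbonyl carbon for a group without a ring, so the direction for an ethoxycarbonyl here is open. The expected step is a number 8 percentage points lower from compound 3 to compound 4 (within the scatter), leaning slightly lower, with a wide range. The estimate for compound 4 in this assay is 40%, expected between 15% and 60%.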

Compound 4, a percentage reported as inhibition, at one concentration (the size of the read-out at that concentration, not a potency): 45%
Estimate against measurement, compound 4: 5 percentage points below, within the range that was stated.
By their numbers in this assay, from the lowest: compound 1; then compounds 4, 3 and 2 (each within the scatter of the next).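

With ethoxycarbonyl in place of phenyl on this carbonyl carbon, a group with no ring leaves the read-out in this assay unchanged within the scatter (a number 3 percentage points lower from compound 3 to compound 4 (within the scatter)), and the whole (ethoxycarbonyl)carbonyl group on the nitrogen likewise shows no change beyond the scatter against hydrogen (a number 5 percentage points lower from compound 2 to compound 4 (within the scatter)), so a phenyl ring at this place is not required to keep the read-out at the level of compound 2 and compound 3. The low number of compound 1 now stands apart from two different groups on the same carbonyl carbon, and the step to the non-ring group is large (a number 40 percentage points higher from compound 1 to compound 4 (beyond the scatter)), which ties the drop to the 3,4-dichlorophenyl group among the four compounds shown rather than to acylation of the nitrogen as such. Nothing available accounts for this pattern.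

Open, on these data alone, is whether a carboxylic acid or a simple methyl on this carbonyl carbon would also stay level with compound 3 and compound 4. As far as these compounds go, it is equally open whether a phenyl carrying a single chlorine already lowers the read-out, or whether both chlorines are needed for the drop seen with compound 1.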